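Triazole-linked aryl variation in a spiro-oxindole antiproliferative series

A few compounds are considered here, and "the series" means these few. Any claim that something is new, unique, unknown or untested is made for them only; others in the source may bear on it.

Measured in a functional assay on A549 cells (Homo sapiens) for antiproliferative activity, read by MTT assay, with a stated time of 48 h; a higher number here means a weaker inhibitor, a lower number a stronger inhibitor:
compound 1 `N#CC1=C(N)Oc2c(N)cc3nc4ccccc4nc3c2C12C(=O)N(Cc1cnnn1-c1ccccc1Br)c1ccccc12` gives 27400 nM
compound 2 `N#CC1=C(N)Oc2c(N)cc3nc4ccccc4nc3c2C12C(=O)N(Cc1cnnn1-c1cccc(C(F)(F)F)c1)c1ccccc12` gives 5400 nM
compound 3 `Cc1ccc(-n2nncc2CN2C(=O)C3(C(C#N)=C(N)Oc4c(N)cc5nc6ccccc6nc5c43)c3ccccc32)cc1Cl` gives 11800 nM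

Compound 3 stands second highest of the three numbers; compound 2 sits at a lower number, compound 1 at a higher one. The two steps touching compound 3 are both changes of the ring on the aromatic nitrogen: a 2.3-fold lower number from compound 1 to compound 3 (0.37 log units; beyond the scatter) and a 2.2-fold higher number from compound 2 to compound 3 (0.34 log units; beyond the scatter). Both are modest, yet beyond the scatter, so swapping this ring does move the read-out, but only within a narrow band.

Compound 4 `Cc1ccc(Cl)cc1-n1nncc1CN1C(=O)C2(C(C#N)=C(N)Oc3c(N)cc4nc5ccccc5nc4c32)c2ccccc21` is the next member. The change from compound 3 is 5-chloro-2-methylphenyl in place of 3-chloro-4-methylphenyl on an aromatic nitrogen; the two have the same atoms, joined differently. Going by the values given here, no measured step bears directly on this rearrangement, since all three measured steps exchange one ring for another of different composition. By analogy to the size of those steps, the step in this assay from compound 3 to compound 4 is expected to be modest at most, and the direction cannot be read from the three measured compounds; the only ring with a substituent next to the attachment, in compound 1, gave the highest number, which points weakly toward a higher value.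

Compound 4 is therefore estimated at 15000 nM, within 6000 nM to 40000 nM, which means an expected step of a 1.3-fold higher number from compound 3 to compound 4 (0.10 log units; within the scatter).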

Compound 4, half-maximal inhibitory concentration: > 50000 nM
Compound 4 was reported as a limit; the forecaster's own chance of this, stated with the estimate: 5%; middle value at least 3.3-fold (0.52 log units) away from the limit.
By their numbers in this assay, from the lowest: compound 2; then compound 3; then compound 1. At a limit, above all of these: compound 4.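

In this assay, compound 4 gives only a limit and not a number: the limit of > 50000 nM in this assay, at which 1 of the 4 values shown sits.

Rearranging the same chlorine and methyl substituents on this ring still gives an at least 4.2-fold higher number from compound 3 to compound 4 (0.62 log units; beyond the scatter), and the comparison with the best of the three earlier compounds gives an at least 9.2-fold higher number from compound 2 to compound 4 (0.96 log units; beyond the scatter), so at this position the arrangement of substituents on the ring matters as well as their identity, something the earlier steps could not show since each exchanged rings of different composition. The 2-bromophenyl of compound 1 and the 5-chloro-2-methylphenyl of compound 4 now both sit at the high end of the series, while the last comparison gives an at least 1.8-fold higher number from compound 1 to compound 4 (0.26 log units; that floor lies within the scatter), so the order of these two stays unsettled, and the link between a substituent numbered 2 on the ring and a high number rests on these two compounds alone.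

The compounds shown leave open whether the 2-methyl group alone carries the change or needs the 5-chloro group with it, a question that a plain 2-methylphenyl or an unsubstituted phenyl would help to separate. Also open, on these data alone, is how this position responds to a ring bearing an amine or a carboxylic acid rather than halogen, methyl or trifluoromethyl groups.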